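The source may hold more compounds than are shown below. What is called first, only, known or untested is meant among the compounds shown, and "the series" means these compounds.

Measured in a functional assay on A549 cells (Homo sapiens) for cytotoxicity, read by MTT assay, with a stated time of 72 h; a higher number here means a weaker inhibitor, a lower number a stronger inhibitor:
compound 1 `Cn1ccc2c(Oc3ccc(NC(=O)c4cc5cccnc5n(-c5ccc(Cl)cc5)c4=O)cc3)ncnc21`: 75500 nM
compound 2 `Cn1ccc2c(Oc3ccc(NC(=O)c4cc5cccnc5n(-c5ccccc5)c4=O)cc3F)ncnc21`: 63200 nM
compound 3 `O=C(Nc1ccc(Oc2ncnc3[nH]ccc23)c(F)c1)c1cc2cccnc2n(-c2ccccc2)c1=O`: 45500 nM

Compound 3, at 45500 nM, lies within the scatter of the other two compounds. Compound 4 `O=C(Nc1ccc(Oc2ncnc3[nH]ccc23)c(F)c1)c1cc2cccnc2n(-c2ccc(Br)cc2F)c1=O` differs from it by having 4-bromo-2-fluorophenyl in place of phenyl on an aromatic nitrogen. Among the measured compounds shown here, the only measured single-place step, a 1.4-fold lower number from compound 2 to compound 3 (0.14 log units; within the scatter), is a different change, hydrogen in place of methyl on an aromatic nitrogen, so it bears on this one only weakly. Compound 1 has 4-chlorophenyl in that place but differs elsewhere too, and it gives 75500 nM, within the scatter of compound 3. No step beyond the scatter is therefore expected in this assay, though the evidence is thin. The expected step is a 1.1-fold lower number from compound 3 to compound 4 (0.06 log units; within the scatter). For compound 4 the estimated value is 40000 nM, with an expected range of 12000 nM to 90000 nM.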

Compound 4, half-maximal inhibitory concentration: 218000 nM
The estimate for compound 4 lay 5.5-fold (0.74 log units) below the measured number; measured number above the stated range.
By their numbers in this assay, from the lowest: compounds 3, 2 and 1 (each within the scatter of the next); then compound 4.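

In this assay, putting 4-bromo-2-fluorophenyl in place of phenyl on the aromatic nitrogen gives a 4.8-fold higher number from compound 3 to compound 4 (0.68 log units; beyond the scatter) and so toward a weaker inhibitor. Among the compounds shown here, this shows that a change at this position can move the number beyond the scatter, which the only earlier step did not show. Nothing given here accounts for the size or direction of this step.

The compounds shown leave open whether the bromine, the fluorine or only the two together carry the step. Going by these compounds, how 2-fluorophenyl, 4-bromophenyl or a phenyl bearing an amine would behave at this position also remains open.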